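Removal of the pyridine methoxy in the indole-pyrimidine amide series

The compounds below may be only part of what the source reports. "The series", "measured", "known", "first", "only" and "open" are said of these compounds alone.

Measured so far in a functional assay on A549 cells (Homo sapiens) for antiproliferative activity, read by MTT assay, with a stated time of 72 h; on this read-out lower numbers stand for stronger inhibition and higher numbers for weaker inhibition:
- compound 1, `COc1cc(F)c(NC(=O)c2ccccn2)cc1Nc1nccc(-c2cn(C)c3ccccc23)n1`, gives 7980 nM
- compound 2, `COc1ccc(C(=O)Nc2cc(Nc3nccc(-c4cn(C)c5ccccc45)n3)c(OC)cc2N(C)C)nc1`, gives 5150 nM

Compound 2 holds the lower of the two numbers, but the gap to compound 1 lies within the scatter of repeated measurements, so the two values are read as equivalent. For the measured compounds named here, no pairwise step between measured compounds exists, as compound 1 and compound 2 differ in more than one place.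

Compound 3, `COc1cc(N(C)C)c(NC(=O)c2ccccn2)cc1Nc1nccc(-c2cn(C)c3ccccc23)n1`, is the next point. It differs from compound 2 by hydrogen in place of methoxy on an aromatic carbon. The amide-bearing fragment is thereby brought back to the plain pyridin-2-yl carbonyl seen in compound 1, while the rest of compound 2 is kept.

Going by the values given here, no measured pair isolates this change, so the expectation rests on the two values alone. Both sit close together, and nothing indicates that the methoxy on the pyridine carries the activity. The expected step from compound 2 to compound 3 in this assay is a 1.3-fold higher number from compound 2 to compound 3 (0.10 log units; within the scatter), that is, no shift beyond the scatter. Compound 3 is therefore estimated at 6500 nM, with a range from 2500 nM to 17000 nM.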

Compound 3, half-maximal inhibitory concentration: 8290 nM
For compound 3 the middle estimate is 1.3-fold (0.11 log units) below the measured one; the measured number falls inside the stated range.
By their numbers in this assay, from the lowest: compounds 2, 1 and 3 (each within the scatter of the next).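

In this assay, 5-methoxypyridin-2-yl and pyridin-2-yl can now be compared directly: the exchange gives a 1.6-fold higher number from compound 2 to compound 3 (0.21 log units; within the scatter) in this pair, so the methoxy on this aromatic carbon, two atoms from the ring nitrogen and para to a large group, has no effect that can be told from the scatter. The result also supplies a second single-place comparison, dimethylamino in place of fluoro on an aromatic carbon, which gives a 1.0-fold higher number from compound 1 to compound 3 (0.02 log units; within the scatter) and likewise stays within the scatter. Neither exchange separates the compounds in this cell assay, so these three groups give no handle on activity at their respective places.

From the compounds shown here alone, whether a carboxylic acid or a morpholine on the pyridine carbon that carries methoxy in compound 2 would shift the number remains open. Also open, going by these compounds, is whether a piperazine in the place of dimethylamino would move the value out of the range held by these three compounds. Nothing available bears on why the values lie so close together.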